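The compounds below may be only part of what the source reports. "The series", "measured", "known", "first", "only" and "open" are said of these compounds alone.

Measured in an in vitro ADME assay on microsomes from liver (Homo sapiens) for metabolic stability, tested at 0.2 uM; a lower number here means slower removal, a higher number faster removal of the compound:
- compound 1 `Cc1ccc2[nH]c(COc3cccc(OCC4CCOCC4)c3)c(C)c(=O)c2c1`: "not determined" (no result reported)
- compound 2 `O=c1c(Cl)c(COc2cccc(OCC3CCOCC3)c2)[nH]c2ccccc12`: 460 mL/min/kg
- compound 3 `CCCCCCCCCc1[nH]c2ccccc2c(=O)c1C`: > 1000 mL/min/kg (a limit of the assay, not a number)

Going by the values given here, compound 2 holds the only actual number in this set, 460 mL/min/kg. Compound 3 gives only a limit, so no step can be read from it. Compound 1 has no result to compare.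

The next compound to be measured is compound 4 `Cc1c(COc2cccc(OCC3CCOCC3)c2)[nH]c2ccccc2c1=O`. It differs from compound 2 by methyl in place of chloro on an aromatic carbon. The exchange lies two atoms from the ring nitrogen, ortho to a large group.

Among the compounds with values here, no measured pair isolates this change, so the expectation in this assay has only one anchor, compound 2 at 460 mL/min/kg. No step beyond the scatter is expected, with a slight lean towards faster removal. The estimated change is a 1.2-fold higher number from compound 2 to compound 4 (0.08 log units; within the scatter). For compound 4 the estimated clearance is 550 mL/min/kg, with an expected range of 280 mL/min/kg to 1000 mL/min/kg.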

Compound 4, clearance: 214 mL/min/kg
Compound 4: the middle estimate sits 2.6-fold (0.41 log units) above what was measured, outside the stated range (below it).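

In this assay, going by these compounds alone, methyl in place of chloro on an aromatic carbon gives a 2.1-fold lower number from compound 2 to compound 4 (0.33 log units; beyond the scatter), the only step in this set that can be read. This position, two atoms from the ring nitrogen and ortho to a large group, therefore responds to its substituent, even though the exchange keeps the heavy-atom count and adds no ring, no hydrogen-bond donors or acceptors and no net charge. Compound 3 alone stands at a limit of the assay, which leaves compound 2 and compound 4 as a pair of actual numbers: the limit of > 1000 mL/min/kg in this assay, at which 1 of the 4 values shown sits.

Steps involving compound 1 or compound 3 cannot be read. Open questions are whether the lower number is particular to methyl or also appears with fluoro, methoxy, nitrile or an amine at this position, whether it holds with a different group in place of the side chain shared by compound 2 and compound 4, and which property of the exchange lies behind the step, since no measured property is available to explain it.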